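The compounds below may be only part of what the source reports. "The series", "measured", "known", "first", "only" and "open" are said of these compounds alone.

The account concerns two amides that share one core and differ in a single place. Compound 1, `C#CCOc1ccc(C(=O)Nc2cccc(C)n2)cc1`, gives 21700 nM in an in vitro assay on HEK-tsA201 cells for antagonist activity at Neuronal acetylcholine receptor; alpha3/beta4 (Homo sapiens), read by fluorescence and calcium flux; on this read-out lower numbers stand for stronger inhibition and higher numbers for weaker inhibition. Compound 2, `CCCOc1ccc(C(=O)Nc2cccc(Br)n2)cc1`, stands at the limit of > 100000 nM in this assay, at which 1 of the 2 values shown sits, so for compound 2 this assay reports only a limit, > 100000 nM, and no number. Compound 3, `CCCOc1ccc(C(=O)Nc2cccc(Nc3ccc(OC)cc3)n2)cc1`, has not yet been measured in this assay. It differs from compound 2 by (4-methoxyphenyl)amino in place of bromo on an aromatic carbon. No measured step joins any two of these compounds, so the size of the change cannot be read from a neighbouring pair; with compound 2 resting at a limit, the step to compound 3 is expected to run toward stronger inhibition, of the size given by an at least 3.3-fold lower number from compound 2 to compound 3 (0.52 log units; beyond the scatter), though a result at the limit again remains possible. Compound 3 is therefore estimated at 30000 nM in this assay, with a range from 8000 nM to 100000 nM.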

Compound 3, half-maximal inhibitory concentration: > 100000 nM
Compound 3: only a limit was reported; the forecaster's own chance of this, stated with the estimate: 35%; at least 3.3-fold (0.52 log units) between middle value and limit.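

In this assay compound 3 gives only a limit, > 100000 nM. Since compound 2 also rests at a limit, no step can be read between compound 2 and compound 3. The compounds shown leave open whether (4-methoxyphenyl)amino in place of bromo changes inhibition at all.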